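From a Ring Amine to a Hydroxy Group on the Core

The source may report more compounds than this note shows. Statements on the series, on what has been measured and on what is new or still open speak of the compounds shown alone.

Compound 1 `CN(C)c1ncnc2c1ncn2CC1CCCCC1` gives 0% in a functional assay on the whole organism for inhibition, with Rattus norvegicus as the target, in the maximal electroshock model, at a dose of 25 mg/kg by the intraperitoneal route; a lower number here means less inhibition, a higher number more inhibition at the dose given (going by the name of the read-out). Compound 2 `CC(C)N(C)c1ncnc2c1ncn2Cc1ccccc1` gives 17% in this assay, and compound 3 `c1ccc(Cn2cnc3c(N4CCC4)ncnc32)cc1` gives 17%, the step of no change at the digits printed from compound 2 to compound 3 (within the scatter) lying within the scatter. Compound 3 thus stands level with compound 2, the two together the highest of the three numbers, while compound 1 lies beyond the scatter below them. Compound 4 `Oc1ncnc2c1ncn2Cc1ccccc1` differs from compound 3 by hydroxy in place of azetidin-1-yl on an aromatic carbon. For the measured compounds named here, no measured step swaps an amine for a hydroxy group; the only one-place step, no change at the digits printed from compound 2 to compound 3 (within the scatter), exchanged one amine for another and changed nothing. The step of a number 7 percentage points lower from compound 3 to compound 4 (within the scatter) is therefore expected to stay small. Compound 4 is estimated at 10%, between 0% and 30%.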

Compound 4, a percentage reported as inhibition, in the whole organism at one dose (the size of the read-out at that dose, not a potency): 17%
Estimate against measurement, compound 4: 7 percentage points below; low and high end bracket the measured number.
By their numbers in this assay, from the lowest: compound 1; then compounds 2, 3 and 4 (each within the scatter of the next).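

In this assay, the earlier step only exchanged one amine for another, whereas here hydroxy brings a hydrogen-bond donor and removes the ring of azetidin-1-yl, yet the result is no change at the digits printed from compound 3 to compound 4 (within the scatter). Set against the isopropyl(methyl)amino group, the result is the same: no change at the digits printed from compound 2 to compound 4 (within the scatter). Among these compounds, then, an amine on this aromatic carbon is not needed to hold the number, and nothing available explains this result. On these data alone, whether a methoxy group or a carboxylic acid at this carbon would give a similar number remains open.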